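The source may hold more compounds than are shown below. What is called first, only, known or untested is meant among the compounds shown, and "the series" means these compounds.

Working notes on the series. In an in vitro ADME assay on microsomes from Gut (Homo sapiens) for metabolic stability, in the presence of a further agent that is not named here (on this read-out lower numbers stand for slow clearance and higher numbers for fast clearance), compound 1 (`COc1ccc(OC(F)(F)F)cc1Cn1c(C(=O)NCC(C)(C)CO)cc2cc(C#N)ccc21`) gives 68 mL.min-1.g-1, compound 2 (`CC(C)(CO)CNC(=O)c1cc2cc(C#N)ccc2n1Cc1cc(Cl)cc(Cl)c1`) gives 98 mL.min-1.g-1 and compound 3 (`COc1ccc(Cl)cc1Cn1c(C(=O)NCC(C)(C)CO)cc2cc(C#N)ccc21`) gives 63 mL.min-1.g-1. Compound 3 therefore stands level with the other two, as all three values lie within the scatter of one another.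

The next entry is compound 4 (`COc1ccc(Br)cc1Cn1c(C(=O)NCC(C)(C)CO)cc2cc(C#N)ccc21`), which has bromo in place of chloro on an aromatic carbon. The swap sits on a six-membered aromatic ring of carbon only, para to a methoxy group.

Going by the values given here, two measured steps bear on this change. The closer one, chloro in place of trifluoromethoxy on an aromatic carbon, gave a 1.1-fold lower number from compound 1 to compound 3 (0.03 log units; within the scatter). The wider one, 5-chloro-2-methoxyphenyl in place of 3,5-dichlorophenyl, gave a 1.6-fold lower number from compound 2 to compound 3 (0.19 log units; within the scatter). Among the compounds with values here, neither step leaves the scatter, and no measured pair has bromo on that carbon. The expectation in this assay is therefore no step beyond the scatter, with no direction favoured.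

The estimated change is a 1.1-fold higher number from compound 3 to compound 4 (0.05 log units; within the scatter), which is expected to stay within the scatter. Compound 4 is estimated at 70 mL.min-1.g-1, with an expected range of 42 mL.min-1.g-1 to 115 mL.min-1.g-1.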

Compound 4, intrinsic clearance in microsomes: 94 mL.min-1.g-1
Beside the measured number, compound 4's estimate is 1.3-fold (0.13 log units) below it; measured number inside the range.
By their numbers in this assay, from the lowest: compounds 3, 1, 4 and 2 (each within the scatter of the next).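

In this assay, bromo in place of chloro on this aromatic carbon, para to a methoxy group, gives a 1.5-fold higher number from compound 3 to compound 4 (0.17 log units; within the scatter) and so adds a second halogen to the substituents tested there without a step that leaves the scatter. The comparisons with the other two compounds read the same way: bromo in place of trifluoromethoxy gives a 1.4-fold higher number from compound 1 to compound 4 (0.14 log units; within the scatter) on this same carbon, and 5-bromo-2-methoxyphenyl in place of 3,5-dichlorophenyl gives a 1.0-fold lower number from compound 2 to compound 4 (0.02 log units; within the scatter) at the level of the whole aryl group, so compounds 1, 3 and 4 together show that chloro, bromo and trifluoromethoxy on this carbon cannot be told apart on this read-out. No measurement to hand offers any explanation for these steps.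

Going by these compounds, it remains open whether an amine or a carboxylic acid on this carbon would give a step beyond the scatter in this assay. Also open, on these data alone, is whether a longer chain in place of the methoxy group, with bromo kept on the ring, would leave the number within the scatter of compound 4.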